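The compounds below may be only part of what the source reports. "The series", "measured", "known", "first", "only" and "open" are said of these compounds alone.

Of the compounds shown here, three have been tested in a functional assay on HepG2 cells (Homo sapiens) for antiproliferative activity, read by MTT assay, with a stated time of 48 h; a higher number here means a weaker inhibitor, a lower number a stronger inhibitor. In it, compound 1 (`COc1cc(/C=C/c2ccc(C(=O)NO)o2)ccc1OCc1ccccc1`) gives 30900 nM, compound 2 (`O=C(/C=C/c1ccc(/C=C/C(=O)c2ccccc2)o1)NO`) gives 12100 nM, and compound 3 (`O=C(CCCCCCC(=O)Nc1ccccc1C(=O)NO)Nc1ccccc1`) gives 63500 nM. Compound 2 therefore has the lowest number of the three and is the strongest inhibitor in this small set, with its gaps to both of the others lying beyond the usual scatter of repeated measurements.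

Compound 4 (`CC(C)c1ccc(C(=O)/C=C/c2ccc(/C=C/C(=O)NO)o2)cc1`) has not yet been measured in this assay. It departs from compound 2 by a single change: isopropyl in place of hydrogen on an aromatic carbon. This places isopropyl in place of hydrogen on an aromatic carbon, para to a large group. Among the compounds with values here, no measured pair in the set shows the effect of such a change, so the expectation is anchored only on compound 2 at 12100 nM. A small move toward a lower number is expected, but none beyond the scatter. The expected step is a 1.3-fold lower number from compound 2 to compound 4 (0.11 log units; within the scatter). For compound 4 the estimated value is 9500 nM, with an expected range from 3500 nM to 26000 nM.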

Compound 4, half-maximal inhibitory concentration: 35900 nM
The estimate for compound 4 lay 3.8-fold (0.58 log units) below the measured number; the whole stated range lies below it.
By their numbers in this assay, from the lowest: compound 2; then compounds 1, 4 and 3 (each within the scatter of the next, the first and the last beyond it).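

In this assay, within the data shown here, the change of hydrogen to isopropyl on an aromatic carbon, para to a large group, gives a 3.0-fold higher number from compound 2 to compound 4 (0.47 log units; beyond the scatter) and is the first single change in this set that can be read. Among these compounds, it shows that this position on the six-membered aromatic ring of carbon only does not take isopropyl without a loss of activity, something the earlier compounds could not show, as none of them differed in one place. Nothing measured here accounts for the loss.

The compounds shown leave open whether the loss is particular to isopropyl or would follow any group at this position, which methyl, methoxy, fluorine or an amine there would help to settle. They also leave open whether isopropyl at another place on this ring would give the same result.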